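The source may report more compounds than this note shows. Statements on the series, on what has been measured and on what is new or still open speak of the compounds shown alone.

Measured compounds in an ADME assay on cells (Rhabdomyosarcoma cell, Homo sapiens) for cytotoxicity, read by MTT assay, with a stated time of 72 h; on this read-out higher numbers stand for lower toxicity in this test and lower numbers for higher toxicity in this test:
- compound 1, `Nc1sc2c(c1-c1nc3cc(Cl)ccc3s1)CCC2`: 59.1 ug/mL
- compound 2, `Fc1ccc(/C=N/c2sc3c(c2-c2nc4ccccc4s2)CCCC3)cc1`: 230 ug/mL

Compound 2 gives the higher of the two numbers in this assay; the gap to compound 1 lies beyond the scatter, so compound 2 is the less toxic of the pair in this test. Among the compounds with values here, no step between measured compounds that differ in a single place is available, so nothing within the set shows the weight of a change on the aryl ring of the imine.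

Compound 3, `Oc1ccccc1/C=N/c1sc2c(c1-c1nc3ccccc3s1)CCCC2`, is the next compound for this assay. It differs from compound 2 as follows: 2-hydroxyphenyl in place of 4-fluorophenyl on a carbon with a double bond to nitrogen. Within the data shown here, with no comparable step measured, the step from compound 2 to compound 3 is expected to be small, a 1.4-fold lower number from compound 2 to compound 3 (0.13 log units; within the scatter), and not clearly beyond the scatter in either direction. Compound 3 is therefore estimated at 170 ug/mL, with a range from 70 ug/mL to 450 ug/mL.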

Compound 3, half-maximal cytotoxic concentration: 42.4 ug/mL
For compound 3 the middle estimate is 4.0-fold (0.60 log units) above the measured one, and the stated range ends above it.
By their numbers in this assay, from the lowest: compounds 3 and 1 (each within the scatter of the next); then compound 2.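

In this assay, the aryl group on the carbon with a double bond to nitrogen proves able to shift the read-out: 2-hydroxyphenyl in place of 4-fluorophenyl gives a 5.4-fold lower number from compound 2 to compound 3 (0.73 log units; beyond the scatter) and makes compound 3 the more toxic of this pair in this test. The entering group carries a hydrogen-bond donor and acceptor that the leaving group lacks, but this single step cannot tie the shift to either feature. No measurement on hand explains the step.

The step changes two things at once, so the loss of fluorine and the gain of hydroxy remain unseparated, and a plain phenyl on the same carbon would be needed to divide them. From the compounds shown here alone, how a methoxyphenyl, an aminophenyl or a pyridyl group would read here also remains open.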